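The compounds below may be only part of what the source reports. "The series", "measured", "known", "first", "only" and "open" are said of these compounds alone.

Measured so far in an ADME assay on HFF cells (Homo sapiens) for cytotoxicity, with a stated time of 8 days; a higher number here means that more compound is tolerated, a lower number that less compound is tolerated:
Compound 1 `CCCCCCSc1nc(N)nc2c1ncn2/C=C1/CC1(CO)CO` gives > 300000 nM, a limit of the assay.
Compound 2 `Nc1nc2c(ncn2/C=C2/CC2(CO)CO)c(=O)[nH]1` gives > 300000 nM, a limit of the assay.
Compound 3 `CCCCOc1nc(N)nc2c1ncn2/C=C1/CC1(CO)CO` gives > 300000 nM, a limit of the assay.

Compound 1 therefore stands at a limit in this assay and not at a number, and the same holds for (the limit of > 300000 nM in this assay, at which 3 of the 3 values shown sit). Among the measured compounds shown here, the one measured step with a single change, a step that the two limits leave unreadable from compound 1 to compound 3, is unreadable for that reason. Compound 4 `Nc1nc(SCc2ccccc2)c2ncn(/C=C3/CC3(CO)CO)c2n1` differs from compound 1 by phenyl in place of pentyl on a saturated chain carbon bound to a sulfur. For the measured compounds named here, no measured step gives a readable size or direction, so compound 4 is expected to sit at the limit as well, and the expected step of a number no higher from compound 1 to compound 4 (the limit leaves the size open) is none beyond the scatter. Compound 4 is estimated at 300000 nM, between 100000 nM and 1000000 nM.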

Compound 4, half-maximal cytotoxic concentration: > 300000 nM
Compound 4: a limit, no number; the forecaster's own chance of this, stated with the estimate: 85%; the middle value sits exactly at the limit.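

No step can be read between compound 4 and compound 1 or compound 3, because all stand at a limit of this assay and not at a number: the limit of > 300000 nM in this assay, at which 4 of the 4 values shown sit.

The compounds shown leave open where any half-maximal cytotoxic concentration actually lies, and whether changing the group on the shared core moves it.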